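The source may hold more compounds than are shown below. What is called first, only, known or untested is meant among the compounds shown, and "the series" means these compounds.

In a physicochemical assay for solubility, measured as kinetic solubility (a lower number here means a less soluble compound, a higher number a more soluble compound), three compounds have been measured so far:
- compound 1 `CCC/N=C1\S/C(=C\c2ccc(O)c(Cl)c2)C(=O)N1C1CCS(=O)(=O)CC1` gives 75000 nM
- compound 2 `CCC/N=C1\S/C(=C\c2ccc(O)c(C#N)c2)C(=O)N1c1ccccc1C` gives 220000 nM
- compound 3 `CCC/N=C1\S/C(=C\c2ccc(O)c(C(C)C)c2)C(=O)N1c1ccccc1C` gives 79000 nM

Compound 1 lies within the scatter of compound 3, and both lie clearly under compound 2, whose number is the highest of the three. The next compound is compound 4 `CCC/N=C1\S/C(=C\c2ccc(O)c(Cl)c2)C(=O)N1c1ccccc1O`, which keeps the core of compound 1 but carries 2-hydroxyphenyl in place of 1,1-dioxothian-4-yl on an amide-type nitrogen in a ring. Within the data shown here, only one measured step is available, a 2.8-fold lower number from compound 2 to compound 3 (0.44 log units; beyond the scatter), and it is an exchange on an aromatic carbon, not on this nitrogen. It therefore offers a sense of scale, a modest step, but no direction. With no measured change at this nitrogen, no shift beyond the scatter is expected in this assay. The expected change is a 1.3-fold lower number from compound 1 to compound 4 (0.10 log units; within the scatter), an estimate that leaves the two compounds about level. For compound 4 the estimated value is 60000 nM, with an expected range from 20000 nM to 160000 nM, and the measurement is still to come.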

Compound 4, solubility: 220000 nM
Compound 4: middle estimate off by 3.7-fold (0.56 log units), on the low side, and the stated range ends below it.
By their numbers in this assay, from the lowest: compounds 1 and 3 (each within the scatter of the next); then compounds 2 and 4 (each within the scatter of the next).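

In this assay, among these compounds, the amide-type nitrogen in the ring proves to be a place where a single exchange moves the number beyond the scatter, something the earlier compounds could not show because their one step lay on an aromatic carbon. With the rest of compound 1 held fixed, 2-hydroxyphenyl in place of 1,1-dioxothian-4-yl gives a 2.9-fold higher number from compound 1 to compound 4 (0.47 log units; beyond the scatter), a step of the same modest grade as a 2.8-fold lower number from compound 2 to compound 3 (0.44 log units; beyond the scatter). No measurement at hand accounts for this rise.

From the compounds shown here alone, how a plain phenyl, a 2-methoxyphenyl or a piperidin-4-yl on this nitrogen would compare in this assay remains open, so the part played by the hydroxy group of 2-hydroxyphenyl cannot be separated from that of the aromatic ring. Going by these compounds, it is also open whether the step would keep its size with a nitrile or an isopropyl group in place of the chlorine of compound 1.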